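This account rests on a few compounds, and the source may have more. Where it says the series, first, only, none or still open, it means among the compounds named here.

Of the compounds shown here, three built on one shared core have been tested in an ADME assay on Raji cells (Homo sapiens) for cytotoxicity, read by CellTiter-Glo and resazurin assay, with a stated time of 72 h; a lower number here means that less compound is needed, a higher number that more compound is needed for the effect. Compound 1 `CC(C)N(Cc1cccc(OCCCCCC(=O)O)c1)C(=O)c1ccccc1` gives > 26000 nM, which is a limit of the assay and not a number. Compound 2 `CC(C)N(Cc1cccc(OCCCCCC(=O)O)c1)C(=O)c1ccc(-c2ccco2)cc1`, with furan-2-yl in place of hydrogen on an aromatic carbon, gives > 26000 nM, again only a limit. Compound 3 `COc1cccc(-c2ccc(C(=O)N(Cc3cccc(OCCCCCC(=O)O)c3)C(C)C)cc2)c1`, with 3-methoxyphenyl in place of hydrogen on an aromatic carbon, gives > 20900 nM, also a limit. Because the limit of > 26000 nM in this assay, at which 2 of the 3 values shown sit, holds two of the three values and the limit of > 20900 nM in this assay, at which 1 of the 3 values shown sits, the third, the steps a step that the two limits leave unreadable from compound 1 to compound 2, a step that the two limits leave unreadable from compound 1 to compound 3 and a step that the two limits leave unreadable from compound 2 to compound 3 cannot be sized, and compound 1 stands among compounds that all sit at a limit. The compound not yet measured, compound 4 `CCOC(=O)CCCCCOc1cccc(CN(C(=O)c2ccccc2)C(C)C)c1`, differs from compound 1 by ethyl in place of hydrogen on an oxygen next to a carbonyl group, that is, carboxy to ethoxycarbonyl. Among the measured compounds shown here, none of the measured steps is readable, so none gives a size for this change, and the expected step from compound 1 to compound 4 in this assay is a number no higher from compound 1 to compound 4 (the limit leaves the size open). Compound 4 is therefore estimated at 26000 nM, within a range from 8000 nM to 80000 nM, most likely reported only as a limit.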

Compound 4, half-maximal effective concentration: > 26000 nM
Compound 4 was reported as a limit; the forecaster's own chance of this, stated with the estimate: 75%; the middle value sits exactly at the limit.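

Compound 1 and compound 4 both sit at a limit, so the step between them cannot be read and the change from carboxy to ethoxycarbonyl gets no size. All four compounds give only limits, which leaves open whether any of these changes moves the value at all.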